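A few compounds are considered here, and "the series" means these few. Any claim that something is new, unique, unknown or untested is made for them only; others in the source may bear on it.

Measured so far in a functional assay on DLD-1 cells (Homo sapiens) for inhibition, with a stated time of 48 h; on this read-out lower numbers stand for stronger inhibition and higher numbers for weaker inhibition:
- compound 1, `COc1ccc2c(=O)cc(/C=C/[S+](C)[O-])oc2c1O`, gives > 10000 nM, a limit of the assay.
- compound 2, `COc1cc2oc(/C=C/[S+](C)[O-])cc(=O)c2cc1OC`, gives 4200 nM.
- compound 3, `C[S+]([O-])/C=C/c1cc(=O)c2cc(O)ccc2o1`, gives > 10000 nM, a limit of the assay.

Among the compounds with values here, compound 2 stands as the only measured number in this assay; the other two results are the limit of > 10000 nM in this assay, at which 2 of the 3 values shown sit. Within the data shown here, no step between two measured compounds can be computed, since no pair differs in one place.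

The next compound is compound 4, `COc1ccc2c(=O)cc(/C=C/[S+](C)[O-])oc2c1`, not yet measured in this assay. From compound 2 it differs by hydrogen in place of methoxy on an aromatic carbon. The change is a loss of a methoxy, ortho to the remaining methoxy group, on the six-membered carbon ring of the fused system, with a hydrogen entering in its place.

Compound 1 and compound 3, which carry a different substitution on that ring, both sit at the limit, while compound 2 with two methoxy groups gives a number. A loss of potency is thought more likely than a gain; the step from compound 2 to compound 4 is expected to be a 1.9-fold higher number from compound 2 to compound 4 (0.28 log units; within the scatter), beyond the scatter but not large. Compound 4 is therefore expected to give 8000 nM, with a range from 2500 nM to 25000 nM.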

Compound 4, half-maximal inhibitory concentration: 1800 nM
For compound 4 the middle estimate is 4.4-fold (0.65 log units) above the measured one; the measured number lies below the stated range.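

Hydrogen in place of methoxy on this aromatic carbon, ortho to a methoxy group, gives a 2.3-fold lower number from compound 2 to compound 4 (0.37 log units; beyond the scatter) in this assay, so the methoxy that leaves is not required for a measurable number on this read-out, and its loss goes with a lower number rather than a higher one. Hydrogen in place of hydroxy on an aromatic carbon points the same way, giving an at least 5.5-fold lower number from compound 1 to compound 4 (0.74 log units; beyond the scatter), and neither listed step goes against this direction. The second step reads only as a bound, since compound 1 sits at a limit of the assay and not at a number: the limit of > 10000 nM in this assay, at which 2 of the 4 values shown sit.

As far as these compounds go, whether any other group on this aromatic carbon, such as fluorine, an amine or a carboxylic acid, would move the number further in either direction stays open, as only hydrogen and methoxy can be compared there. From the compounds shown here alone, the side chain carrying the sulfur is the same in all four compounds, so its share in the activity also stays open, and a shorter or longer chain in its place could settle that.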